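This account rests on a few compounds, and the source may have more. Where it says the series, first, only, none or still open, it means among the compounds named here.

The measured compounds:

compound 1 `COc1ccc(F)cc1CNCCCNc1ccnc2cc(Cc3ccc(C#N)cc3)ccc12` — 6050 nM
compound 2 `COc1ccc(-c2ccc3c(NCCCNCc4ccco4)ccnc3c2)cc1` — 6000 nM
compound 3 `COc1cccc(CNCCCNc2ccnc3cc(Cc4ccc(C#N)cc4)ccc23)c1O` — 7150 nM

All three were tested in an ADME assay on HepG2 cells (Homo sapiens) for cytotoxicity, read by luminescence, CellTiter-Glo and ATP content, with a stated time of 72 h; on this read-out lower numbers stand for an effect already at smaller amounts and higher numbers for an effect only at larger amounts of compound. On these numbers compound 1 stands second highest of three. Its nearest neighbour is compound 2, whose value sits within the scatter of that of compound 1, so the two cannot be told apart. Its furthest neighbour is compound 3, yet even that step is small: a 1.2-fold higher number from compound 1 to compound 3 (0.07 log units; within the scatter), a change at the benzylamine end of the molecule that left the read-out where it was.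

Compound 4 `COc1ccc(F)cc1CNCCCNc1ccnc2cc(Cc3ccc(F)cc3)ccc12` is the next compound. It differs from compound 1 at the other end of the shared core: fluoro in place of cyano on an aromatic carbon. Among the compounds with values here, no measured step touches this position, so the only guide is that the one step known here, from compound 1 to compound 3, stayed within the scatter. The expectation is therefore a step of about a 1.0-fold lower number from compound 1 to compound 4 (0.00 log units; within the scatter), none beyond the scatter. Compound 4 is estimated at 6000 nM, within 3000 nM to 12000 nM.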

Compound 4, half-maximal effective concentration: 3530 nM
Beside the measured number, compound 4's estimate is 1.7-fold (0.23 log units) above it, within the range that was stated.
By their numbers in this assay, from the lowest: compounds 4, 2, 1 and 3 (each within the scatter of the next, the first and the last beyond it).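

Within the data shown here, this is the first look at the far end of the shared core, and it shows that replacing cyano with fluoro does not move the number in this assay beyond the usual scatter (a 1.7-fold lower number from compound 1 to compound 4 (0.23 log units; within the scatter)). The exchange swaps two heavy atoms for one and removes a hydrogen-bond acceptor, yet compounds 1 and 4 still cannot be told apart. This step is larger than the one at the benzylamine end, but both lie within the scatter, so neither end has yet shown a real effect, and nothing available explains the size of this step.

Going by these compounds, it remains open whether a very different group at this place, such as a carboxylic acid or a trifluoromethyl, would shift the number beyond the scatter. On these data alone, it is also open whether fluoro would behave the same way with the 2-hydroxy-3-methoxyphenyl end of compound 3.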